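The source may hold more compounds than are shown below. What is called first, only, known or untested is meant among the compounds shown, and "the series" means these compounds.

Measured so far in a toxicity assay on cells (Macrophage, Mus musculus, strain BALB/c) for cytotoxicity, read by MTT assay; on this read-out higher numbers stand for weaker inhibition and lower numbers for stronger inhibition
- compound 1 `COc1cc(O)cc(O)c1C(=O)/C=C/c1ccc(C)cc1` gives 16500 nM
- compound 2 `COc1cc(O)cc(O)c1C(=O)/C=C/c1ccc(F)cc1` gives 28800 nM
- compound 3 `COc1cc(O)cc(O)c1C(=O)/C=C/c1ccccc1Br` gives 14600 nM

Compound 3 at 14600 nM stands within the scatter of both other compounds, with a 1.1-fold lower number from compound 1 to compound 3 (0.05 log units; within the scatter) and a 2.0-fold lower number from compound 2 to compound 3 (0.30 log units; within the scatter) as the two measured steps to it. Next comes compound 4 `COc1cc(O)cc(O)c1C(=O)/C=C/Cc1ccccc1` and the change is benzyl in place of 2-bromophenyl on a double-bonded chain carbon bound to a double-bonded chain carbon in which benzyl takes the place of 2-bromophenyl on a double-bonded chain carbon bound to a double-bonded chain carbon.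

The two steps to compound 3 bear on this most directly, as both replace the group at that same place. A third step, a 1.7-fold higher number from compound 1 to compound 2 (0.24 log units; within the scatter) on the same set, is a smaller guide. For the measured compounds named here, no measured compound carries a benzyl, so the series offers only indirect evidence. Even the widest pair, compound 2 at 28800 nM and compound 3 at 14600 nM in this set, stays within the scatter, so no step beyond the scatter is expected in this assay for this change. The estimate implies a 1.4-fold higher number from compound 3 to compound 4 (0.14 log units; within the scatter) as the expected step. For compound 4 the estimated value is 20000 nM with an expected range from 9000 nM to 45000 nM in this read-out.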

Compound 4, half-maximal inhibitory concentration: 27000 nM
Estimate against measurement, compound 4: 1.4-fold (0.13 log units) below; the range from low to high includes it.
By their numbers in this assay, from the lowest: compounds 3, 1, 4 and 2 (each within the scatter of the next).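

Working notes on the series: in this assay, benzyl on a double-bonded chain carbon bound to a double-bonded chain carbon is the first group at this place that is not a substituted phenyl, and the swap from 2-bromophenyl, at an equal count of heavy atoms but with bromine gone, stays within the scatter (a 1.8-fold higher number from compound 3 to compound 4 (0.27 log units; within the scatter)). The two other steps to benzyl, from 4-fluorophenyl (a 1.1-fold lower number from compound 2 to compound 4 (0.03 log units; within the scatter)) and from 4-methylphenyl (a 1.6-fold higher number from compound 1 to compound 4 (0.21 log units; within the scatter)), also stay within the scatter, so at this place all four groups shown are unresolved from one another on this read-out. No accompanying data bear on these steps, so the values give no explanation for them.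

Still open, going by these compounds, is whether a group of another kind at this place, such as an amine, a carboxylic acid or a longer chain ending in a phenyl ring, would give a step beyond the scatter. The hydroxy and methoxy groups on the shared core are the same in all four compounds, so the compounds shown say nothing about changes there.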